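A few compounds are considered here, and "the series" means these few. Any claim that something is new, unique, unknown or untested is made for them only; others in the source may bear on it.

Working notes on the sulfonamide series. Among the compounds with values here, the three measured members share one core and differ only on the sulfonyl sulfur: compound 1 `O=S(=O)(Nc1ccc(-c2nc3ccccc3o2)cc1)c1ccc(Cl)c(C(F)(F)F)c1`, compound 2 `O=S(=O)(Nc1ccc(-c2nc3ccccc3o2)cc1)c1cccc(O)c1` and compound 3 `CS(=O)(=O)Nc1ccc(-c2nc3ccccc3o2)cc1`. In an assay on cells for inhibition of HSP60/HSP10 (Homo sapiens), with a stated time of 60 min (on this read-out lower numbers stand for stronger inhibition and higher numbers for weaker inhibition), compound 1 gives 12000 nM and compound 2 gives 62000 nM. For compound 3 this assay reports only a limit, > 100000 nM, so compound 3 stands at the weak end of the series without a number of its own. Within the data shown here, the one single-point step measured so far runs toward it: an at least 1.6-fold higher number from compound 2 to compound 3 (0.20 log units; that floor lies within the scatter).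

The next compound, compound 4 `O=S(=O)(Nc1ccc(-c2nc3ccccc3o2)cc1)c1ccc(Cl)c(Cl)c1`, reverses the direction of that step. Change: 3,4-dichlorophenyl in place of methyl on a sulfonyl sulfur. Among the measured compounds shown here, the only measured step that touches this position is the one from compound 2 to compound 3, and it reached at least the floor of the scatter. Compound 1, which also carries a chlorine-bearing phenyl on the sulfonyl sulfur, sits at 12000 nM, well inside the measurable range; compound 3 does not. On that basis a large drop in this assay is expected for compound 4, the step being estimated as an at least 10-fold lower number from compound 3 to compound 4 (1.00 log units; beyond the scatter). The estimate for compound 4 in this assay is 10000 nM, with a range from 3500 nM to 30000 nM.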

Compound 4, half-maximal inhibitory concentration: 25000 nM
The estimate for compound 4 lay 2.5-fold (0.40 log units) below the measured number; the range from low to high includes it.
By their numbers in this assay, from the lowest: compound 1; then compound 4; then compound 2. At a limit, above all of these: compound 3.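

Putting 3,4-dichlorophenyl in place of methyl on the sulfonyl sulfur gives an at least 4.0-fold lower number from compound 3 to compound 4 (0.60 log units; beyond the scatter), a step that clears the scatter, though it can be read only as a floor because compound 3 stands at a limit: the limit of > 100000 nM in this assay, at which 1 of the 4 values shown sits.

The phenyl ring alone does not set the number, as the groups it carries also matter: 3,4-dichlorophenyl in place of 3-hydroxyphenyl gives a 2.5-fold lower number from compound 2 to compound 4 (0.39 log units; beyond the scatter). The position also responds to a single group on the ring, with chloro in place of trifluoromethyl on an aromatic carbon giving a 2.1-fold higher number from compound 1 to compound 4 (0.32 log units; beyond the scatter), so the two chlorine-bearing phenyl compounds remain separable.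

From the compounds shown here alone, it remains open whether a longer chain or a benzyl group on the sulfonyl sulfur would bring the number into the measurable range, or whether an aromatic ring there is required. Also open, going by these compounds, is how an amine, a carboxylic acid or a single chloro on the phenyl ring would compare with the 3-hydroxyphenyl and 3,4-dichlorophenyl groups.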